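Propoxy in place of benzyloxy on a biphenyl acid

The compounds below may be only part of what the source reports. "The series", "measured", "known", "first", "only" and "open" are said of these compounds alone.

Measured compounds:
compound 1, `Cc1cc(OCCOCc2ccccc2)cc(C)c1-c1cccc(COc2ccc(OCC(=O)O)c(F)c2)c1`, "not determined" (no result reported) in a functional assay on CHO cells for agonist activity at Free fatty acid receptor 1 (Homo sapiens), read by FLIPR and calcium flux; a lower number here means that less compound is needed, a higher number that more compound is needed for the effect
compound 2, `Cc1cc(OCCCS(C)(=O)=O)ccc1-c1cccc(COc2ccc(OCC(=O)O)c(F)c2)c1`, 43.6 nM in this assay
compound 3, `Cc1cc(OCCCS(C)(=O)=O)cc(C)c1-c1cccc(COc2ccc(N(CC(=O)O)C(=O)c3ccoc3)cc2)c1`, "not determined" (no result reported) in this assay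

Compound 1 stands without a number: in this assay the entry for compound 1 reads "not determined" (no result reported), and the entry for compound 3 reads "not determined" (no result reported). For the measured compounds named here, the only number among the three belongs to compound 2, which in this assay gives 43.6 nM. Compound 4, `CCCOc1cc(C)c(-c2cccc(COc3ccc(OCC(=O)O)c(F)c3)c2)c(C)c1`, differs from compound 1 in one place: methyl in place of benzyloxy on a saturated chain carbon, two bonds along the chain from an oxygen on an aromatic ring. Going by the values given here, no step between measured compounds is known that would show what such a change does, and compound 1 itself carries no number to step from. The account therefore rests on compound 2 as the nearest measured relative, which shares the acid-bearing part of the core and the biphenyl with compound 4, while differing in the chain on the outer ring and in the number of methyl groups. On that basis compound 4 is expected to land in the same region as compound 2, with a wide range to reflect the missing step; the estimate for compound 4 in this assay is 70 nM, between 20 nM and 250 nM.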

Compound 4, half-maximal effective concentration: 106 nM
Compound 4: the middle estimate sits 1.5-fold (0.18 log units) below what was measured; low and high end bracket the measured number.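

With no single number shown for compound 1, no step from it to compound 4 can be read. The compounds shown leave open what 2-(benzyloxy)ethoxy to propoxy does on its own. No evidence bearing on this result is at hand.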